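The compounds below may be only part of what the source reports. "The series", "measured", "known", "first", "only" and "open" are said of these compounds alone.

Working notes on the series. Compound 1 `O=C(Nc1cccc(-n2cc(-c3ccncc3)c(-c3ccc(Cl)c(O)c3)n2)c1)Nc1cccc(C(F)(F)F)c1`, compound 2 `COc1cc(-c2nn(-c3cccc(NC(=O)Nc4cccc(C(F)(F)F)c4)c3)cc2-c2ccncc2)ccc1Cl` and compound 3 `COc1cc(-c2nn(-c3cccc(NC(=O)Nc4ccc(Cl)c(C(F)(F)F)c4)c3)cc2-c2ccncc2)ccc1Cl` share one core and have been run in a functional assay on ACHN cells (Homo sapiens) for inhibition, read by sulforhodamine B assay, with a stated time of 48 h; on this read-out higher numbers stand for lower toxicity in this test and lower numbers for higher toxicity in this test. Compound 1 gives > 32500 nM, which is a limit of the assay and not a number. Compound 2 gives > 50000 nM in this assay, again only a limit. Compound 3 gives > 32500 nM in this assay, likewise a limit. The cores of compound 2 and compound 3 differ by chloro in place of hydrogen on an aromatic carbon; the step that the two limits leave unreadable from compound 2 to compound 3 stays unreadable because the limit of > 32500 nM in this assay, at which 2 of the 3 values shown sit, and the limit of > 50000 nM in this assay, at which 1 of the 3 values shown sits, are where the two values sit. The change hydrogen in place of methyl on an oxygen on an aromatic ring gives the step that the two limits leave unreadable from compound 2 to compound 1, unreadable for the same reason.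

Compound 4 `O=C(Nc1cccc(-n2cc(-c3ccncc3)c(-c3ccc(Cl)c(O)c3)n2)c1)Nc1ccc(Cl)c(C(F)(F)F)c1` is not yet measured. It differs from compound 3 by hydrogen in place of methyl on an oxygen on an aromatic ring, the same change as from compound 2 to compound 1, the place being identical in both. In this assay the expected step that the limit leaves unreadable from compound 3 to compound 4 is small. This expectation rests on compound 1, whose limit > 32500 nM carries the same hydroxy group. Compound 4 is therefore estimated at 40000 nM, expected between 20000 nM and 100000 nM, most likely reported as a limit.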

Compound 4, concentration lethal to 50% of the cells: > 32500 nM
Compound 4 was reported as a limit; the forecaster's own chance of this, stated with the estimate: 85%; the middle value lies beyond the limit too.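

The steps to compound 4 from compound 3 and from compound 1 cannot be read, because all three compounds sit at one limit of the assay: the limit of > 32500 nM in this assay, at which 3 of the 4 values shown sit.

The compounds shown leave open where any of them truly lies beyond its limit in this assay, and whether methoxy to hydroxy or chloro in place of hydrogen changes the read-out at all.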